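A few compounds are considered here, and "the series" means these few. Any claim that something is new, unique, unknown or untested is made for them only; others in the source may bear on it.

Measured compounds in a physicochemical assay for solubility, measured as thermodynamic solubility, with a stated time of 24 h, at pH 6.8; on this read-out lower numbers stand for lower solubility and higher numbers for higher solubility:
- compound 1, `Cc1cc(C)c2cc(C(=O)NC3CCCCC3)[nH]c2c1`: compound 1 gives a limit, < 4000 nM
- compound 2, `Cc1cc(C)c2cc(C(=O)NC3CCN(C)CC3)[nH]c2c1`: compound 2 gives a limit, > 10000000 nM
- compound 3, `Cc1cc(C)c2cc(C(=O)NC(C)C)[nH]c2c1`: compound 3 gives 20000 nM

Compound 3 is the only one of the three with a proper number in this assay; the other two values are limits, as given by the limit of < 4000 nM in this assay, at which 1 of the 3 values shown sits, and (the limit of > 10000000 nM in this assay, at which 1 of the 3 values shown sits). Compound 4, `CCC(C)NC(=O)c1cc2c(C)cc(C)cc2[nH]1`, has not been measured. It differs from compound 3 by methyl in place of hydrogen on a saturated chain carbon, two bonds along the chain from an amide-type nitrogen, so the isopropyl on the amide nitrogen becomes sec-butyl.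

The step that bears on this is an at least 5.0-fold higher number from compound 1 to compound 3 (0.69 log units; beyond the scatter), where a smaller alkyl on the amide nitrogen went with a higher number. The step of an at least 2500-fold higher number from compound 1 to compound 2 (3.39 log units; beyond the scatter) concerns a different kind of group and does not inform this change. Since compound 4 grows the alkyl again, but only by one methyl, the estimate is a small drop from compound 3 in this assay, probably near the scatter: a 1.7-fold lower number from compound 3 to compound 4 (0.22 log units; within the scatter) is expected. Compound 4 is therefore expected to give about 12000 nM, within 4000 nM to 30000 nM.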

Compound 4, solubility: 22000 nM
Estimate against measurement, compound 4: 1.8-fold (0.26 log units) below; low and high end bracket the measured number.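

In this assay, methyl in place of hydrogen on a saturated chain carbon, two bonds along the chain from an amide-type nitrogen, gives a 1.1-fold higher number from compound 3 to compound 4 (0.04 log units; within the scatter) and so isopropyl and sec-butyl cannot be told apart at this position. Sec-butyl stands apart from the two larger groups, with an at least 5.5-fold higher number from compound 1 to compound 4 (0.74 log units; beyond the scatter) against cyclohexyl and an at least 450-fold lower number from compound 2 to compound 4 (2.65 log units; beyond the scatter) against 1-methylpiperidin-4-yl, and each of these steps starts from a limit of the assay and gives only a minimum size. Nothing measured here accounts for the methyl making no difference beyond the scatter.

The compounds shown leave open how far the alkyl group can grow before the number falls, as with a longer chain such as n-hexyl. They also leave open whether an open-chain amine such as 2-(dimethylamino)ethyl could stand in for 1-methylpiperidin-4-yl.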